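The compounds below may be only part of what the source reports. "The series", "measured", "known", "first", "only" and "open" are said of these compounds alone.

Within the data shown here, compound 2 `CC(C)N(C(=O)CN1C=CN(c2ccccc2)C(=O)C(Cc2n[nH]c3ccccc23)C1=O)c1ccc(F)cc1` is the only compound with a single number in a functional assay on CHO cells for agonist activity at Melanocortin receptor 4 (Homo sapiens), read by a luciferase reporter, with a stated time of 4 h; on this read-out higher numbers stand for an effect only at larger amounts of compound and lower numbers for an effect already at smaller amounts: in this assay compound 2 gives 282 nM, with one further entry that carries no single number. Compound 1 `COc1ccc(N(C(=O)CN2C=CN(c3ccccc3)C(=O)[C@@H](Cc3n[nH]c4ccccc34)C2=O)C(C)C)cc1` gives 31600 nM; > 30000 nM (2 entries) in this assay, taken over several entries. Compound 3 `COc1ccc(N(C(=O)CN2C=CN(c3ccccc3)C(=O)C(Cc3n[nH]c4ccccc34)C2=O)C(C)C)cc1` has not yet been measured in this assay. It differs from compound 2 by methoxy in place of fluoro on an aromatic carbon. No step between two measured compounds is shown that matches this change. The expectation for compound 3 rests on compound 1, whose entries the several entries of compound 1 in this assay, 31600 nM; > 30000 nM (2 entries) stand far from the number of compound 2, so a large loss of effect is expected, a 21-fold higher number from compound 2 to compound 3 (1.33 log units; beyond the scatter). Compound 3 is expected to give about 6000 nM, within 800 nM to 40000 nM, with a fair chance that only a limit is reported.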

Compound 3, half-maximal effective concentration: 708 nM
Compound 3: middle estimate off by 8.5-fold (0.93 log units), on the high side; the whole stated range lies above it.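

In this assay, the change from 4-fluorophenyl to 4-methoxyphenyl gives a 2.5-fold higher number from compound 2 to compound 3 (0.40 log units; beyond the scatter), so a methoxy group at this place, para to a large group, costs only a modest part of the effect seen with fluoro. Compound 1 carries the same methoxy group, yet its entries, which include limits of the assay, lie much higher: the several entries of compound 1 in this assay, 31600 nM; > 30000 nM (2 entries). The methoxy group alone therefore does not account for those entries, and the gap may instead lie with the configuration: the fact that one of compounds 1 and 3 is drawn with a defined configuration and the other without, at the place where they differ.

From the compounds shown here alone, it remains open how other groups at this place would read, such as an amine, a chloro atom or a longer ether like ethoxy. Also open, going by these compounds, is how the opposite configuration of compound 1 would read.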